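Chloro for ethyl on the amide aryl ring

This account rests on a few compounds, and the source may have more. Where it says the series, first, only, none or still open, it means among the compounds named here.

Two compounds have numbers in a functional assay on SK-BR-3 cells (Homo sapiens) for antiproliferative activity, read by MTT assay, with a stated time of 72 h; on this read-out lower numbers stand for stronger inhibition and higher numbers for weaker inhibition. Compound 1 `Cc1cc(NCCN2CCN(C)CC2)nc2ccc(NC(=O)c3ccc(Cl)c(Cl)c3)cc12` gives 2690 nM in this assay. Compound 2 `CCc1ccccc1C(=O)Nc1ccc2nc(N3CCN(CC)CC3)cc(C)c2c1` gives 23900 nM in this assay, the highest of the two numbers; its gap to compound 1 lies beyond the scatter, but the two compounds differ in several places, so no single change can be read from that gap.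

Compound 3 `CCN1CCN(c2cc(C)c3cc(NC(=O)c4ccccc4Cl)ccc3n2)CC1` differs from compound 2 in one place: chloro in place of ethyl on an aromatic carbon. Within the data shown here, no measured pair isolates this change, so the expectation for compound 3 rests on compound 2 alone. The change is expected to give only a small step, within the scatter, with no firm direction: a 1.6-fold lower number from compound 2 to compound 3 (0.20 log units; within the scatter). Compound 3 is accordingly expected to give about 15000 nM in this assay, with a range from 5000 nM to 45000 nM.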

Compound 3, half-maximal inhibitory concentration: > 50000 nM
Compound 3: a limit, no number; the forecaster's own chance of this, stated with the estimate: 10%; at least 3.3-fold (0.52 log units) between middle value and limit.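

In this assay, chloro in place of ethyl on an aromatic carbon, ortho to a large group, is not a neutral change at this position: it gives an at least 2.0-fold higher number from compound 2 to compound 3 (0.32 log units; beyond the scatter). Compound 3 gives > 50000 nM, which is a limit of the assay and not a number. The full size of the step stays unknown, and only its direction and minimum can be read, because the value of compound 3 is bounded from one side: the limit of > 50000 nM in this assay, at which 1 of the 3 values shown sits.

This single pair cannot say whether other groups at this position, such as methoxy or an amine, would track the ethyl or the chloro compound. It also leaves open whether the same change would have a similar effect on a compound carrying the side chain of compound 1.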